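The compounds below may be only part of what the source reports. "The series", "measured", "known", "first", "only" and "open" are said of these compounds alone.

Measured compounds:
- compound 1, `CCCC(=O)N1CCC(NS(=O)(=O)c2ccc(NC(=O)c3ccc(F)cc3)c3ccccc23)CC1`, in an in vitro functional assay on CHO/Galpha16 cells for antagonist activity at C-C chemokine receptor type 8 (Homo sapiens), read by FLIPR (a lower number here means a stronger inhibitor, a higher number a weaker inhibitor), gives 59.5 nM
- compound 2, `CCCC(=O)N1CCC(NS(=O)(=O)c2ccc(NC(=O)c3cc(C)nc(Cl)c3)c3ccccc23)CC1`, in this assay gives 43.9 nM

Compound 1 has the highest of the two numbers; its nearest neighbour is compound 2, reached by a 1.4-fold lower number from compound 1 to compound 2 (0.13 log units; within the scatter), so the two cannot be ranked against each other. Compound 3, `CCCC(=O)N1CCC(NS(=O)(=O)c2ccc(NC(=O)C3CCC3)c3ccccc23)CC1`, has not yet been measured. It differs from compound 1 in one place: cyclobutyl in place of 4-fluorophenyl on a carbonyl carbon. Among the measured compounds shown here, the only measured step, from compound 1 to compound 2, also swaps the group on that carbonyl carbon, but exchanges one six-membered aromatic ring for another and stays within the scatter. For the measured compounds named here, no measured step exchanges an aromatic ring for a four-membered non-aromatic ring, so the data give no direction for this change. Compound 3 is therefore expected to give 90 nM, within 25 nM to 350 nM. That estimate means an expected step of a 1.5-fold higher number from compound 1 to compound 3 (0.18 log units; within the scatter), with wide uncertainty.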

Compound 3, half-maximal inhibitory concentration: 57.9 nM
Compound 3: middle estimate off by 1.6-fold (0.19 log units), on the high side; the measured number falls inside the stated range.
By their numbers in this assay, from the lowest: compounds 2, 3 and 1 (each within the scatter of the next).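

In this assay, cyclobutyl on the carbonyl carbon cannot be told apart from 4-fluorophenyl (a 1.0-fold lower number from compound 1 to compound 3 (0.01 log units; within the scatter)) or from 2-chloro-6-methylpyridin-4-yl (a 1.3-fold higher number from compound 2 to compound 3 (0.12 log units; within the scatter)). Among the compounds shown here, until now this position had been seen only with six-membered aromatic rings, and these three compounds show that a four-membered non-aromatic ring of carbon only, with fewer heavy atoms, gives a number in the same range, so an aromatic ring is not required here. Nothing measured here explains why the three groups read alike.

Still open, on these data alone, is whether this position needs a ring at all, which an open chain such as butyl would test. Also open, as far as these compounds go, is how it would respond to a group carrying a charge or a hydrogen-bond donor on the ring, such as an amine or a carboxylic acid.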